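Exchanging the Aryl Group on the Shared Core's Amine Nitrogen

This account rests on a few compounds, and the source may have more. Where it says the series, first, only, none or still open, it means among the compounds named here.

Compound 2 `N#Cc1c(Nc2cccc(Cl)c2)nc(SCc2cn(Cc3ccccc3Cl)nn2)nc1-c1ccccc1` gives 3590 nM in a functional assay on B16-F10 cells (Mus musculus) for inhibition, read by MTT assay, with a stated time of 72 h; on this read-out lower numbers stand for stronger inhibition and higher numbers for weaker inhibition. Compound 1 `COc1ccc(Nc2nc(SCc3cn(Cc4ccccc4Cl)nn3)nc(-c3ccccc3)c2C#N)cc1` gives 3990 nM in this assay, and the two numbers sit within the scatter of each other. Compound 3 `COc1ccccc1Nc1nc(SCc2cn(Cc3ccccc3Cl)nn2)nc(-c2ccccc2)c1C#N` carries 2-methoxyphenyl in place of 3-chlorophenyl on a nitrogen on an aromatic ring. For the measured compounds named here, only one measured step bears on this change, the earlier exchange of the group on the same nitrogen, a 1.1-fold lower number from compound 1 to compound 2 (0.05 log units; within the scatter). Because a 1.1-fold lower number from compound 1 to compound 2 (0.05 log units; within the scatter) stayed within the scatter, no shift beyond the scatter is expected here, an estimated step of a 1.0-fold higher number from compound 2 to compound 3 (0.01 log units; within the scatter). Compound 3 is therefore expected at 3700 nM, within a range from 1500 nM to 9000 nM.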

Compound 3, half-maximal inhibitory concentration: 7860 nM
Estimate against measurement, compound 3: 2.1-fold (0.33 log units) below, within the range that was stated.
By their numbers in this assay, from the lowest: compounds 2, 1 and 3 (each within the scatter of the next, the first and the last beyond it).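

Exchanging the aryl group on this nitrogen can move the number beyond the scatter, though only modestly: 3-chlorophenyl to 2-methoxyphenyl gives a clear step (a 2.2-fold higher number from compound 2 to compound 3 (0.34 log units; beyond the scatter)). Exchanging 4-methoxyphenyl for 2-methoxyphenyl does not clear the scatter (a 2.0-fold higher number from compound 1 to compound 3 (0.29 log units; within the scatter)), so only compound 2 and compound 3 can be told apart. No available evidence accounts for this shift. Still open, going by these compounds, is how this position would respond to an unsubstituted phenyl, or to an aryl group carrying an amine or a carboxylic acid.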